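The source may hold more compounds than are shown below. What is called first, only, known or untested is meant among the compounds shown, and "the series" means these compounds.

Compound 1 `CC(=O)CC[C@]1(C(C)=O)C(=O)O[C@@H](OC(C)=O)[C@H]1C` gives 7000 nM in a functional assay on B16 cells (Mus musculus) for cytotoxicity, read by MTT assay; a lower number here means a stronger inhibitor, a higher number a weaker inhibitor. Compound 2 `CC(=O)O[C@@H]1OC(=O)[C@](O)(C(C)=O)[C@@H]1C` reaches only a limit of this assay, > 50000 nM. Compound 3 `CC(=O)O[C@@H]1OC(=O)[C@](OC(=O)c2ccccc2)(C(C)=O)[C@@H]1C` gives 6000 nM.

Among the two numbers shown, compound 1 stands highest, and the nearest, compound 3, lies within the scatter of it, so no order between those two can be read. The value of compound 2 is a limit, not a number (the limit of > 50000 nM in this assay, at which 1 of the 3 values shown sits).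

Compound 4 `CC(=O)O[C@@H]1OC(=O)[C@](Br)(C(C)=O)[C@@H]1C` has not been measured. It differs from compound 1 in one place: bromo in place of 2-acetylethyl on a saturated ring carbon. Going by the values given here, one measured step bears on this position, an at least 7.1-fold higher number from compound 1 to compound 2 (0.85 log units; beyond the scatter), where a hydroxy took the same place; it went to a limit. Compound 3, with a benzoyloxy at that carbon, stays near compound 1. The bromo brings neither donor nor acceptor, unlike both of those groups, so the step is expected to be a 2.1-fold higher number from compound 1 to compound 4 (0.33 log units; beyond the scatter), upward and probably beyond the scatter. Compound 4 is therefore estimated at 15000 nM, expected to fall between 3000 nM and 60000 nM.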

Compound 4, half-maximal inhibitory concentration: 9000 nM
Compound 4: middle estimate off by 1.7-fold (0.22 log units), on the high side, within the range that was stated.
By their numbers in this assay, from the lowest: compounds 3, 1 and 4 (each within the scatter of the next). At a limit, above all of these: compound 2.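

In this assay, replacing the whole 2-acetylethyl with a single bromo atom gives a 1.3-fold higher number from compound 1 to compound 4 (0.11 log units; within the scatter) and so leaves no readable difference, which shows that this chain is not required at this ring carbon for the level of compound 1. The same bromo set against the hydroxy gives an at least 5.5-fold lower number from compound 2 to compound 4 (0.74 log units; beyond the scatter) and places compound 2 apart from compounds 1, 3 and 4, so among the groups shown at this carbon, only the hydroxy goes against the otherwise close values. As far as these compounds go, for compound 2, > 50000 nM is a limit and not a number, so the full size of that gap stays unknown.

From the compounds shown here alone, whether an amine or a carboxylic acid at this carbon would stay with compounds 1, 3 and 4 or go with compound 2 remains open. So does the result with a methoxy, which would show whether the hydroxy's hydrogen matters.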